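The source may hold more compounds than are shown below. What is called first, only, known or untested is meant among the compounds shown, and "the series" means these compounds.

Two compounds share one core and differ only in the aromatic group attached to a carbonyl carbon. Compound 1 `COc1cc(C2CC(=NOC(=O)c3ccc(Cl)cc3)CC(c3ccc(O)c(OC)c3)N2C)ccc1O` carries a 4-chlorophenyl there, and in a functional assay, read by spectrophotometry, with a stated time of 30 min (a lower number here means a stronger inhibitor, a higher number a weaker inhibitor), compound 1 gives 112000 nM. Compound 2 `COc1cc(C2CC(=NOC(=O)c3cccc(O)c3)CC(c3ccc(O)c(OC)c3)N2C)ccc1O` carries a 3-hydroxyphenyl instead, and in this assay compound 2 gives 16500 nM. Among the measured compounds shown here, the step of a 6.8-fold lower number from compound 1 to compound 2 (0.83 log units; beyond the scatter) is the only measured comparison, and it leaves compound 2 with the lowest of the two numbers, compound 1 standing higher by a margin beyond the scatter. Compound 3 `COc1cc(C2CC(=NOC(=O)c3ccc(Br)cc3)CC(c3ccc(O)c(OC)c3)N2C)ccc1O` turns back toward compound 1: 4-bromophenyl in place of 3-hydroxyphenyl on a carbonyl carbon. The 4-bromophenyl that enters resembles the 4-chlorophenyl of compound 1 far more than the 3-hydroxyphenyl it replaces, so the measured step of a 6.8-fold lower number from compound 1 to compound 2 (0.83 log units; beyond the scatter) is expected to run roughly backwards, giving a higher number. For compound 3 the expected value in this assay is 100000 nM, with a likely range from 35000 nM to 300000 nM. That expectation amounts to a step of a 6.1-fold higher number from compound 2 to compound 3 (0.78 log units; beyond the scatter).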

Compound 3, half-maximal inhibitory concentration: 108000 nM
Estimate against measurement, compound 3: 1.1-fold (0.03 log units) below; low and high end bracket the measured number.
By their numbers in this assay, from the lowest: compound 2; then compounds 3 and 1 (each within the scatter of the next).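

In this assay, bromo in place of chloro on an aromatic carbon gives a 1.0-fold lower number from compound 1 to compound 3 (0.02 log units; within the scatter) and so the 4-chlorophenyl and 4-bromophenyl groups cannot be told apart here. The step of a 6.5-fold higher number from compound 2 to compound 3 (0.82 log units; beyond the scatter) shows that the lower number of compound 2 does not survive with either of these two halogens, so it stays tied, among these compounds, to the 3-hydroxyphenyl group. Nothing available explains why the 3-hydroxyphenyl group gives the lowest number of the three.

Because the hydroxy group and the halogen also carry different numbers in their group names, these compounds cannot separate the identity of the group from where it sits, which 4-hydroxyphenyl and 3-bromophenyl could address. Also open, on these data alone, is how plain phenyl, 3-aminophenyl or a phenyl bearing a carboxylic acid would compare with compound 2.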